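Extending a Hydroxyalkyl Carbamate Chain: What to Expect

The source may hold more compounds than are shown below. What is called first, only, known or untested is meant among the compounds shown, and "the series" means these compounds.

Compound 1 `CC(C)(N)C(=O)N[C@H](COCc1ccccc1)c1nnnn1CCOC(=O)NCCO` gives 3 nM in a functional assay on H4 cells with growth hormone secretagogue receptor type 1 (Homo sapiens) as the target, read by FLIPR; on this read-out lower numbers stand for an effect already at smaller amounts and higher numbers for an effect only at larger amounts of compound.
Compound 2 `CC(C)(N)C(=O)N[C@H](COCc1ccccc1)c1nnnn1CCOC(=O)NCCCO` gives 5.5 nM in this assay.

Compound 2 stands highest of the two numbers measured, with compound 1 its nearest neighbour at a distance within the scatter. Compound 3 `CC(C)(N)C(=O)N[C@H](COCc1ccccc1)c1nnnn1CCOC(=O)NCCCCCO` differs from compound 2 by 2-hydroxyethyl in place of hydroxy on a saturated chain carbon, three bonds along the chain from an amide-type nitrogen, so the hydroxyalkyl chain grows longer again. Among the compounds with values here, the one step that bears on this is a 1.8-fold higher number from compound 1 to compound 2 (0.26 log units; within the scatter), a hydroxymethyl in place of hydroxy, which stayed within the scatter. A comparable outcome is therefore expected in this assay, with no clear shift or a small drift upward. Compound 3 is estimated at 7 nM, between 2.5 nM and 20 nM. That estimate corresponds to an expected 1.3-fold higher number from compound 2 to compound 3 (0.10 log units; within the scatter).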

Compound 3, half-maximal effective concentration: 14.6 nM
For compound 3 the middle estimate is 2.1-fold (0.32 log units) below the measured one, within the range that was stated.
By their numbers in this assay, from the lowest: compounds 1 and 2 (each within the scatter of the next); then compound 3.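

In this assay, within the data shown here, moving to the 5-hydroxypentyl chain gives a 2.7-fold higher number from compound 2 to compound 3 (0.42 log units; beyond the scatter) and is the first single step here to lie beyond the scatter. Measured from the shortest chain, the change amounts to a 4.9-fold higher number from compound 1 to compound 3 (0.69 log units; beyond the scatter) and shows that the number at this position does respond to chain length, which compounds 1 and 2 alone could not show. Nothing available gives a reason for this rise. Still open, going by these compounds, is whether a chain longer than 5-hydroxypentyl would raise the number further. Also open, on these data alone, is how an amine or a carboxylic acid at the chain end would compare with the hydroxy.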